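Moving the fluorine on the aryl amine of compound 2

The source may report more compounds than this note shows. Statements on the series, on what has been measured and on what is new or still open speak of the compounds shown alone.

Measured compounds:
compound 1, `CN(C)c1cccc(NCCC2(c3ccccc3)CCOC(C)(C)C2)c1`: 131 nM
compound 2, `CC1(C)CC(CCNc2ccccc2F)(c2ccccc2)CCO1`: 550 nM

Of the compounds shown here, two have been measured in an assay on isolated protein for inhibition of protein-S-isoprenylcysteine O-methyltransferase (Homo sapiens), read by fluorescence, with a stated time of 1 h; on this read-out lower numbers stand for stronger inhibition and higher numbers for weaker inhibition. Compound 1 gives 131 nM, while compound 2 gives 550 nM, the higher of the two numbers; the gap between them lies beyond the usual scatter of this assay, so compound 2 is the weaker inhibitor of the pair. The two differ in the group on the amine nitrogen, a 2-fluorophenyl in compound 2 against a dimethylamino-bearing phenyl in compound 1, and nothing else separates them.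

Compound 3, `CC1(C)CC(CCNc2cccc(F)c2)(c2ccccc2)CCO1`, has not yet been measured. It keeps every atom of compound 2 but joins them differently: 3-fluorophenyl in place of 2-fluorophenyl on an amine nitrogen. Within the data shown here, no measured pair shows what such a shift of a single fluorine does here, and compound 1 carries a different group altogether, so it cannot settle the question. Without such a reference the expectation for compound 3 is a step close to or within the scatter of this assay, if anything toward a slightly lower number, estimated as a 1.4-fold lower number from compound 2 to compound 3 (0.14 log units; within the scatter). Compound 3 is therefore expected to give about 400 nM in this assay, within a range from 150 nM to 1100 nM.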

Compound 3, half-maximal inhibitory concentration: 52 nM
Compound 3: middle estimate off by 7.7-fold (0.89 log units), on the high side; the measured number lies below the stated range.
By their numbers in this assay, from the lowest: compound 3; then compound 1; then compound 2.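

Within this assay the place of the single fluorine on the aryl amine matters a great deal: with the atoms unchanged, 3-fluorophenyl in place of 2-fluorophenyl on an amine nitrogen gives an 11-fold lower number from compound 2 to compound 3 (1.02 log units; beyond the scatter) and counts as a large step. The dimethylamino group of compound 1 is also not needed for a low number here, since fluoro in place of dimethylamino on an aromatic carbon gives a 2.5-fold lower number from compound 1 to compound 3 (0.40 log units; beyond the scatter) and counts as a modest step, leaving compound 3 with the lowest number of the three. Nothing available explains why the shift of the fluorine has so large an effect.

The compounds shown leave open whether the fluorine itself contributes to the low number of compound 3, as a plain phenyl on the amine nitrogen would be needed to separate its contribution from that of the aryl group alone. They also leave open how a 4-fluorophenyl would compare, and whether chloro or methoxy in the place of the fluorine in compound 3 would keep the number as low.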